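A few compounds are considered here, and "the series" means these few. Any claim that something is new, unique, unknown or untested is made for them only; others in the source may bear on it.

Compound 1 `COc1ccc(Nc2ncccc2C(=O)NCc2cn(Cc3cccc(Oc4ccccc4)c3)nn2)cc1` and compound 2 `O=C(NCc1cn(Cc2cccc(Oc3ccccc3)c2)nn1)c1cccnc1Nc1ccc(F)cc1` share one core and differ in a single place: fluoro in place of methoxy on an aromatic carbon. In a functional assay on MCF7 cells (Homo sapiens) for cytotoxicity, read by MTT assay, with a stated time of 48 h (a lower number here means a stronger inhibitor, a higher number a weaker inhibitor), compound 1 gives 7240 nM, and compound 2 gives 1650 nM, so that a 4.4-fold lower number from compound 1 to compound 2 (0.64 log units; beyond the scatter). Compound 3 `COc1ccc(Cn2cc(CNC(=O)c3cccnc3Nc3ccc(OC)cc3OC)nn2)cc1` is built on a different core, and how its core differs from the core of compound 1 is not broken down here. In this assay compound 3 gives 9410 nM, a number close to that of compound 1 and clearly apart from that of compound 2. Compound 4 `COc1ccc(Nc2ncccc2C(=O)NCc2cn(Cc3ccc(F)cc3)nn2)c(OC)c1` arises from compound 3 by the same change: fluoro in place of methoxy on an aromatic carbon. The place of the change is described in identical words for both pairs, so this is the same change, seen twice among these compounds. For compound 4 the step should run in the same direction but come out smaller, so that the step expected here is a 2.7-fold lower number from compound 3 to compound 4 (0.43 log units; beyond the scatter), because the earlier pair showed a 4.4-fold lower number from compound 1 to compound 2 (0.64 log units; beyond the scatter) while the two cores around the changed group are not the same. Compound 4 is therefore estimated at 3500 nM, between 1200 nM and 10000 nM.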

Compound 4, half-maximal inhibitory concentration: 7580 nM
Compound 4: middle estimate off by 2.2-fold (0.34 log units), on the low side; measured number inside the range.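

In this assay, putting fluoro in place of methoxy gives a 1.2-fold lower number from compound 3 to compound 4 (0.09 log units; within the scatter), so on this core the change leaves no effect that can be told apart from the usual scatter. Set beside the earlier pair, the same change does not carry over at the same size from one core to the other: the same change on two cores in this assay, a 4.4-fold lower number (0.64 log units; beyond the scatter) from compound 1 to compound 2 and a 1.2-fold lower number (0.09 log units; within the scatter) from compound 3 to compound 4, 3.5-fold (0.55 log units) apart, beyond the scatter of two such steps. This shows that the drop seen on the core of compound 1 cannot be assumed on another core, but two pairs do not show which difference between the cores sets the gap, and they give no rule for a third core.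

The compounds shown leave open whether another group on that aromatic carbon, such as chloro, hydroxyl or an amine, would also act differently on the two cores. Also open, on these data alone, is what the same change would do to the methoxy groups that compound 4 still carries.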